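The source may report more compounds than this note shows. Statements on the series, on what has been measured and on what is new or still open speak of the compounds shown alone.

Measured compounds:
compound 1, `COc1ccc(CN2C(=O)/C(=C\c3cc(OC)c(OC)c(OC)c3)c3ccccc32)cc1`: 2000 nM
compound 2, `COc1cc(/C=C2\C(=O)N(C)c3ccc(Cl)cc32)cc(OC)c1OC`: 4700 nM

Both were tested in a functional assay on cells (Cancer cell lines, Homo sapiens) for cytotoxicity, with a stated time of 48 h; a higher number here means a weaker inhibitor of growth, a lower number a stronger inhibitor of growth. Compound 1 gives 2000 nM and compound 2 gives 4700 nM; compound 1 thus has the lower of the two numbers, and its gap to compound 2 lies beyond the usual scatter. Nothing further can be said of that pair, as the two compounds differ in more than one place.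

Compound 3, `COc1cc(/C=C2\C(=O)N(Cc3ccc(Cl)cc3)c3ccccc32)cc(OC)c1OC`, is not yet measured. It differs from compound 1 in one place: chloro in place of methoxy on an aromatic carbon. Within the data shown here, no pair of measured compounds isolates this change, so there is no measured step to lean on. Given that compound 1 stands at 2000 nM, only a small step is expected in this assay, slightly toward a higher number, if any. The expected step is a 1.3-fold higher number from compound 1 to compound 3 (0.10 log units; within the scatter), within the scatter. Compound 3 is therefore estimated to give about 2500 nM, with a likely range from 1000 nM to 6000 nM.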

Compound 3, concentration for 50% growth inhibition: 2500 nM
Compound 3: the middle estimate sits on the measured number at the digits printed; measured number inside the range.
By their numbers in this assay, from the lowest: compounds 1, 3 and 2 (each within the scatter of the next, the first and the last beyond it).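

Among these compounds, compound 3 gives the first comparison in which only one place differs: in this assay the move from 4-methoxybenzyl to 4-chlorobenzyl is a 1.3-fold higher number from compound 1 to compound 3 (0.10 log units; within the scatter) and stays within the scatter. On this aromatic carbon, para to a large group, methoxy can therefore be exchanged for chloro, a group with one heavy atom fewer and no hydrogen-bond acceptor, without a difference that can be told from the scatter, so for this pair the methoxy oxygen is not needed. Nothing measured here offers a reason for this result.

Going by these compounds, whether other groups at this place would read alike, such as an amine, a carboxylic acid or a longer alkoxy chain, remains open. On these data alone, it is also open how a plain benzyl, with no group on this carbon, would compare.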